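Propyl for isopropyl on a triazine-fused core at the limit

This account rests on a few compounds, and the source may have more. Where it says the series, first, only, none or still open, it means among the compounds named here.

Measured so far in a functional assay for inhibition, with Homo sapiens as the target; a higher number here means a weaker inhibitor, a lower number a stronger inhibitor:
compound 1 `CCCc1nc(C)c2c(C(C)C)nnc(O)n12` gives > 48000 nM, a limit of the assay.
compound 2 `C=CCn1ncc2c(C)nc(CC)n2c1=O` gives > 48000 nM, a limit of the assay.
compound 3 `CCCc1nc(C)c2c(C(C)C)nnc(S)n12` gives > 48000 nM, a limit of the assay.

Where compound 1 stands: only a limit is known for compound 1, and the two other values in this assay are limits as well, so compound 1 cannot be ordered against either of them.

The step to consider is propyl in place of isopropyl on an aromatic carbon, giving compound 4 `CCCc1nnc(O)n2c(CCC)nc(C)c12`. Within the data shown here, the one measured step that changes a single group on the core of compound 1, a step that the two limits leave unreadable from compound 1 to compound 3, is unreadable, since both ends sit at the limit; the limit of > 48000 nM in this assay, at which 3 of the 3 values shown sit, describes the whole picture so far. Among the measured compounds shown here, no measured step speaks to the exchange of isopropyl for propyl at that position, and nothing in the three measured values gives any compound a readable number.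

The expectation for compound 4 is therefore a value at or beyond the limit, with the step that the limit leaves unreadable from compound 1 to compound 4 expected to be none beyond the scatter. Compound 4 is estimated at 100000 nM, within 30000 nM to 400000 nM.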

Compound 4, half-maximal inhibitory concentration: 16000 nM
The estimate for compound 4 lay 6.3-fold (0.80 log units) above the measured number; measured number below the stated range.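

In this assay, among these compounds, compound 4 gives 16000 nM, the first number that is not a limit. The exchange of isopropyl for propyl gives an at least 3.0-fold lower number from compound 1 to compound 4 (0.47 log units; beyond the scatter), so this position on the aromatic carbon, para to a hydroxy group, can change the read-out even though the two compounds have the same atoms, joined differently. The earlier step on the core of compound 1 cannot be read, and the remaining values give no order: the limit of > 48000 nM in this assay, at which 3 of the 4 values shown sit.

Going by these compounds, whether a longer chain such as butyl, or an amine, at this position would lower the number further stays open. Also open, on these data alone, is whether sulfanyl in place of hydroxy becomes readable on the core of compound 4, where propyl lifts the value off the limit.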